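Swapping a trifluoromethyl-bearing benzyl for a fluorobenzyl

The compounds below may be only part of what the source reports. "The series", "measured", "known", "first", "only" and "open" are said of these compounds alone.

Three measured compounds share one core and differ only in the group on a saturated chain carbon bound to an oxygen on an aromatic ring. In a functional assay on MNK45 cells (Homo sapiens) for inhibition, read by MTT assay, with a stated time of 48 h (a higher number here means a weaker inhibitor, a lower number a stronger inhibitor), compound 1 `Cc1ccc(NC(=O)NC(=O)c2ccc(OCc3ccccc3)cc2)cc1-c1nc2ccccc2[nH]1` gives 35100 nM. Compound 2 `Cc1ccc(NC(=O)NC(=O)c2ccc(OCc3ccc(C(F)(F)F)cc3)cc2)cc1-c1nc2ccccc2[nH]1` gives 16800 nM, and compound 3 `Cc1ccc(NC(=O)NC(=O)c2ccc(OCc3cccc(C(F)(F)F)c3)cc2)cc1-c1nc2ccccc2[nH]1` gives 9600 nM. Compound 3 has the lowest of the three numbers, yet its gap to compound 2, a 1.8-fold lower number from compound 2 to compound 3 (0.24 log units; within the scatter), lies within the scatter, so these two cannot be ranked against each other. The clearer steps are a 2.1-fold lower number from compound 1 to compound 2 (0.32 log units; beyond the scatter) and a 3.7-fold lower number from compound 1 to compound 3 (0.56 log units; beyond the scatter). Compound 4 `Cc1ccc(NC(=O)NC(=O)c2ccc(OCc3ccccc3F)cc2)cc1-c1nc2ccccc2[nH]1` carries the change (2-fluorophenyl in place of 3-(trifluoromethyl)phenyl on a saturated chain carbon bound to an oxygen on an aromatic ring). Among the compounds with values here, this removes the trifluoromethyl whose addition gave a 3.7-fold lower number from compound 1 to compound 3 (0.56 log units; beyond the scatter), and brings in a single fluorine that no measured compound tests. The step from compound 1 to compound 3 therefore bears on it in reverse: a rise in number back toward compound 1 is expected, with the fluorine as an open question. For compound 4 the expected step is a 2.6-fold higher number from compound 3 to compound 4 (0.42 log units; beyond the scatter). Compound 4 is estimated at 25000 nM, ranging from 8000 nM to 70000 nM.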

Compound 4, half-maximal inhibitory concentration: 1830 nM
Compound 4: the middle estimate sits 14-fold (1.14 log units) above what was measured; the whole stated range lies above it.
By their numbers in this assay, from the lowest: compound 4; then compounds 3 and 2 (each within the scatter of the next); then compound 1.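

At this position, the largest step among these compounds comes with a single fluoro in place of hydrogen, a 19-fold lower number from compound 1 to compound 4 (1.28 log units; beyond the scatter) in this assay, so a trifluoromethyl group is not needed for a low number here. The 2-fluorophenyl group also gives a lower number than either trifluoromethyl-bearing group, with a 5.2-fold lower number from compound 3 to compound 4 (0.72 log units; beyond the scatter) and a 9.2-fold lower number from compound 2 to compound 4 (0.96 log units; beyond the scatter) in the same assay, even though compound 2 and compound 3 cannot be ranked against each other. Nothing available explains this gain.

The change from compound 3 to compound 4 alters both the group and where it sits on the ring, so the two effects cannot be separated. A 4-fluorophenyl, 2-chlorophenyl or 2-(trifluoromethyl)phenyl group would be needed to show whether the fluorine itself or its place matters more.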